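The compounds below may be only part of what the source reports. "The series", "measured", "known", "first", "only" and "open" are said of these compounds alone.

Compound 1 `CCOC(=O)CNC(=O)NC1CC2CCC1(C)C2(C)C` gives > 2000000 nM
Compound 2 `CC1(C)[C@@H]2CC[C@@]1(C)C(NC(=O)Nc1ccccc1F)C2` gives 225000 nM

Among the measured compounds shown here, in a physicochemical assay for solubility, in phosphate buffer, at pH 7.4 (a lower number here means a less soluble compound, a higher number a more soluble compound), compound 2 stands at 225000 nM, the only actual number so far. For compound 1 , > 2000000 nM is a limit of the assay and not a number. Compound 3 `CC1(C)C2CCC1(C)C(NC(=O)Nc1ccccc1F)C2` is the next to be measured, and it differs from compound 2 only in how its stereochemistry is drawn: the two compounds have the same atoms and bonds; at least one stereo element is drawn with a configuration in one of them and without one in the other: 2 of 3 stereo elements differ; a stereocentre at a saturated ring carbon is drawn R in compound 2 and without a configuration in compound 3; a stereocentre at a saturated ring carbon is drawn R in compound 2 and without a configuration in compound 3. For the measured compounds named here, no measured step is available as a guide, so the expectation rests on compound 2 at 225000 nM and is for no change beyond the scatter in this assay. The expected step is no change at the digits printed from compound 2 to compound 3 (within the scatter). Compound 3 is estimated at 225000 nM, with an expected range from 110000 nM to 450000 nM.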

Compound 3, solubility: 225000 nM
Compound 3: middle estimate and measured number agree at the digits printed; the range from low to high includes it.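

In this assay, among the compounds shown here, there is no change at the digits printed from compound 2 to compound 3 (within the scatter), and the only contrast in that pair lies in how the configuration is drawn: the fact that one of compounds 2 and 3 is drawn with a defined configuration and the other without, at the place where they differ With 2-fluorophenyl in place of (ethoxycarbonyl)methyl on an amide-type nitrogen, there is an at least 8.8-fold lower number from compound 1 to compound 3 (0.94 log units; beyond the scatter). For compound 1, the value of > 2000000 nM is a limit of the assay and not a number.

The compounds shown leave open whether the opposite configuration at those ring carbons would read differently in this assay. They also leave open how a carboxylic acid in place of the (ethoxycarbonyl)methyl ester, or a pyridyl in place of 2-fluorophenyl, would read there.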